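The source may hold more compounds than are shown below. What is called first, only, known or untested is meant among the compounds shown, and "the series" means these compounds.

Of the compounds shown here, three built on one shared core have been tested in an assay on isolated protein for inhibition of Rho-associated protein kinase 2 (Homo sapiens), read by scintillation counting, radiometric assay and 33P incorporation, with a stated time of 40 min, in the presence of a further agent that is not named here; on this read-out lower numbers stand for stronger inhibition and higher numbers for weaker inhibition. Compound 1 `CC(=O)Nc1cccc(NC(=O)COc2ccc3c(=O)ccoc3c2)c1` gives 136 nM, compound 2 `CCOc1ccc(C(=O)Nc2cccc(NC(=O)COc3ccc4c(=O)ccoc4c3)c2)cc1` gives 9 nM, and compound 3 `COC(=O)c1ccc(C(=O)Nc2cccc(NC(=O)COc3ccc4c(=O)ccoc4c3)c2)cc1` gives 29 nM. Compound 3 thus holds the second highest number of the three: a 3.2-fold higher number from compound 2 to compound 3 (0.51 log units; beyond the scatter), while a 4.7-fold lower number from compound 1 to compound 3 (0.67 log units; beyond the scatter) and a 15-fold lower number from compound 1 to compound 2 (1.18 log units; beyond the scatter). Compound 4 `Cc1cc(C(=O)Nc2cccc(NC(=O)COc3ccc4c(=O)ccoc4c3)c2)no1` differs from compound 3 by 5-methyl-1,2-oxazol-3-yl in place of 4-(methoxycarbonyl)phenyl on a carbonyl carbon. All three measured steps alter the substituent on this same carbonyl carbon, yet none of them tests a five-membered aromatic ring there, so only a modest step in this assay, with uncertain direction, is expected. The step from compound 3 to compound 4 is therefore estimated as a 1.4-fold higher number from compound 3 to compound 4 (0.14 log units; within the scatter). Compound 4 is expected to give 40 nM, somewhere between 12 nM and 130 nM.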

Compound 4, half-maximal inhibitory concentration: 5 nM
For compound 4 the middle estimate is 8.0-fold (0.90 log units) above the measured one, outside the stated range (below it).
By their numbers in this assay, from the lowest: compounds 4 and 2 (each within the scatter of the next); then compound 3; then compound 1.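

In this assay, a five-membered aromatic ring on this carbonyl carbon is compatible with strong inhibition: replacing the larger 4-(methoxycarbonyl)phenyl with 5-methyl-1,2-oxazol-3-yl gives a 5.8-fold lower number from compound 3 to compound 4 (0.76 log units; beyond the scatter), and replacing methyl gives a 27-fold lower number from compound 1 to compound 4 (1.43 log units; beyond the scatter). Replacing 4-ethoxyphenyl gives a 1.8-fold lower number from compound 2 to compound 4 (0.26 log units; within the scatter), so a six-membered ring of carbon only is not required here. No available evidence bears on these steps. The compounds shown leave open what the methyl on the new ring contributes, and how a thiophene or piperidine ring on this carbonyl carbon would compare.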